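The compounds below may be only part of what the source reports. "The series", "measured", "known", "first", "only" and "open" are said of these compounds alone.

Three analogues share one core, measured in a functional assay on HEK293 cells for agonist activity at Toll-like receptor 8 (Homo sapiens), read by reporter gene assay; a higher number here means that more compound is needed for the effect, a lower number that less compound is needed. Compound 1 `CCCCCNc1oc2c(C)ncc(CO)c2c1Nc1ccccn1` gives 5810 nM. Compound 2 `CCCCNc1oc2c(C)ncc(CO)c2c1Nc1ccccn1` gives 9380 nM, the only difference between them being the step of a 1.6-fold higher number from compound 1 to compound 2 (0.21 log units; within the scatter), which stays within the scatter. Compound 3 `Cc1ncc(CO)c2c(Nc3ccccc3)c(NCc3ccccc3)oc12`, which differs at several places, gives 1680 nM; set beside compound 2, its number is clearly lower, beyond the scatter, so compound 2 sits at the upper end of the three numbers while being indistinguishable from compound 1.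

Compound 4 `CCOC(=O)CNc1oc2c(C)ncc(CO)c2c1Nc1ccccn1` arises from compound 2 through the change (ethoxycarbonyl in place of propyl on a saturated chain carbon bound to a nitrogen on an aromatic ring). For the measured compounds named here, the only measured step that touches this place is a 1.6-fold higher number from compound 1 to compound 2 (0.21 log units; within the scatter), and it shows that lengthening or shortening the saturated chain by one carbon changes nothing beyond the scatter. Going by the values given here, no measured pair shows an ester or any oxygen-bearing group on that chain, so nothing anchors the direction. Given that the chain-length step stayed flat, compound 4 is expected to move only modestly, with a step of a 1.6-fold higher number from compound 2 to compound 4 (0.20 log units; within the scatter) toward a higher number; the estimate for compound 4 is 15000 nM, in the range 4000 nM to 60000 nM.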

Compound 4, half-maximal effective concentration: "not active" (no number reported)
Nothing numeric was reported for compound 4; there is nothing to compare the estimate with.
By their numbers in this assay, from the lowest: compound 3; then compounds 1 and 2 (each within the scatter of the next).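

For the compounds shown here, compound 4 was reported as "not active" without a number, so no step from compound 2 to compound 4 can be read. Nothing measured here accounts for this result. The compounds shown leave open whether compound 4's missing activity comes from ethoxycarbonyl itself or would extend to other oxygen-bearing chains.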